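The source may report more compounds than this note shows. Statements on the series, on what has been measured and on what is new or still open speak of the compounds shown alone.

Measured in a functional assay (strain AB) with Danio rerio as the target, read by microscopy, with a stated time of 1 h; a higher number here means that more compound is needed for the effect, a lower number that less compound is needed:
Compound 1 `CCN1CCc2c(sc(NC(=O)Nc3ccccc3)c2C(N)=O)C1`: > 25000 nM, a limit
Compound 2 `CCN1CCc2c(sc(NC(=O)NCC3CCCO3)c2C(N)=O)C1`: > 25000 nM, a limit
Compound 3 `CCN1CCc2c(sc(NC(=O)Nc3cccc(C)c3)c2C(N)=O)C1`: 13000 nM

Compound 3 is the only one of the three with an actual number. The other two values are limits: the limit of > 25000 nM in this assay, at which 2 of the 3 values shown sit.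

Compound 4 `CCN1CCc2c(sc(NC(=O)Nc3ccc(I)cc3)c2C(N)=O)C1` has not been measured. It carries 4-iodophenyl in place of 3-methylphenyl on an amide-type nitrogen.

Among the compounds with values here, two measured steps bear on this change: an at least 1.9-fold lower number from compound 1 to compound 3 (0.28 log units; that floor lies within the scatter), and an at least 1.9-fold lower number from compound 2 to compound 3 (0.28 log units; that floor lies within the scatter). Each gives only a floor, and neither floor goes beyond the scatter, so they support no large move in this assay.

The expected change is therefore small: a 1.2-fold lower number from compound 3 to compound 4 (0.07 log units; within the scatter). For compound 4 the estimated value is 11000 nM, with an expected range of 3500 nM to 30000 nM.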

Compound 4, half-maximal effective concentration: 1620 nM
Compound 4: the middle estimate sits 6.8-fold (0.83 log units) above what was measured; the whole stated range lies above it.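

In this assay, the group on this amide-type nitrogen can move the number well beyond the scatter: 4-iodophenyl in place of 3-methylphenyl gives an 8.0-fold lower number from compound 3 to compound 4 (0.90 log units; beyond the scatter). Iodo in place of hydrogen gives an at least 15-fold lower number from compound 1 to compound 4 (1.18 log units; beyond the scatter), and 4-iodophenyl in place of (oxolan-2-yl)methyl gives an at least 15-fold lower number from compound 2 to compound 4 (1.18 log units; beyond the scatter). These last two steps are floors, since compound 1 and compound 2 each carry a limit: the limit of > 25000 nM in this assay, at which 2 of the 4 values shown sit.

Whether the iodine itself or its place on the ring matters more stays open, as would be shown by 3-iodophenyl or 4-methylphenyl. From the compounds shown here alone, how 4-chlorophenyl or an amine on that ring would read also remains open.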